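Two fluorines on the benzyl arm: expected cytotoxicity

A few compounds are considered here, and "the series" means these few. Any claim that something is new, unique, unknown or untested is made for them only; others in the source may bear on it.

Measured compounds:
compound 1 `CCOC(=O)/C(O)=C/C(=O)c1cn(Cc2cccc(F)c2)c2cccc(OC)c12` with 63200 nM
compound 2 `COc1cccc2c1c(C(=O)/C=C(\O)C(=O)O)cn2Cc1cccc(F)c1` with 65800 nM

In an ADME assay on MT4 cells (Homo sapiens) for cytotoxicity, read by MTT assay (a higher number here means that more compound is tolerated, a lower number that less compound is tolerated), compound 1 gives 63200 nM, the lowest of the two numbers, and compound 2 gives 65800 nM. The two values lie within the scatter of each other, so nothing separates them: a 1.0-fold higher number from compound 1 to compound 2 (0.02 log units; within the scatter).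

Compound 3 `CCOC(=O)/C(O)=C/C(=O)c1cn(Cc2ccc(F)cc2F)c2cccc(OC)c12` has not yet been measured. It differs from compound 1 in one place: 2,4-difluorophenyl in place of 3-fluorophenyl on a saturated chain carbon bound to an aromatic nitrogen. Among the measured compounds shown here, the one measured step, from compound 1 to compound 2, changes the ester oxygen and leaves the benzyl arm untouched, so it says nothing about the fluorine pattern on that ring. For the measured compounds named here, no measured step bears on the change from compound 1 to compound 3. With nothing pointing up or down, the expectation is that compound 3 stays close to compound 1, with no step beyond the scatter: a 1.0-fold lower number from compound 1 to compound 3 (0.00 log units; within the scatter). The estimate for compound 3 in this assay is therefore 63000 nM, with a range from 30000 nM to 130000 nM.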

Compound 3, half-maximal cytotoxic concentration: 65500 nM
Compound 3: middle estimate off by 1.0-fold (0.02 log units), on the low side; the measured number falls inside the stated range.
By their numbers in this assay, from the lowest: compounds 1, 3 and 2 (each within the scatter of the next).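

In this assay, among the compounds shown here, replacing 3-fluorophenyl with 2,4-difluorophenyl gives a 1.0-fold higher number from compound 1 to compound 3 (0.02 log units; within the scatter), and this is the first view of the benzyl arm, since the earlier step changed only the ethyl group on the ester oxygen. For this pair, then, a second fluorine and a different fluorine pattern on the ring, on a saturated chain carbon bound to an aromatic nitrogen, produce no change that can be told apart from the scatter of repeated measurements, so this read-out does not separate the two arms. Nothing measured here offers an explanation for this result.

From the compounds shown here alone, all three compounds carry at least one fluorine on the benzyl ring and a single carbon linking that ring to the aromatic nitrogen, so it remains open whether a plain benzyl, a benzyl ring bearing an amine, or a longer chain in place of that single carbon would stay equally well tolerated. Also open, going by these compounds, is whether the 2,4-difluorobenzyl arm behaves the same way when the ethyl ester gives way to the free carboxylic acid of compound 2.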